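Replacing the 2-chlorophenyl group of compound 2

The source may hold more compounds than are shown below. What is called first, only, known or untested is meant among the compounds shown, and "the series" means these compounds.

compound 1 `NC(=O)c1c(NC(=O)c2ccccc2Cl)sc2c1CCNC2`: 18600 nM
compound 2 `NC(=O)c1c(NC(=O)c2ccccc2Cl)sc2c1CCN(Cc1ccc(Cl)cc1Cl)C2`: 8010 nM

In a functional assay on HL-60 cells (Homo sapiens) for antiproliferative activity, with a stated time of 24 h (on this read-out lower numbers stand for stronger inhibition and higher numbers for weaker inhibition), compound 2 holds the lower of the two numbers (8010 nM). Going by the values given here, the only measured step (a 2.3-fold lower number from compound 1 to compound 2 (0.37 log units; beyond the scatter)) is modest and comes with 2,4-dichlorobenzyl in place of hydrogen on an amine nitrogen in a ring.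

Compound 3 `NC(=O)c1c(NC(=O)c2ccc(C(F)(F)F)cc2)sc2c1CCN(Cc1ccc(Cl)cc1Cl)C2` keeps that 2,4-dichlorobenzyl group. Its difference from compound 2 is 4-(trifluoromethyl)phenyl in place of 2-chlorophenyl on a carbonyl carbon. Among the compounds with values here, both measured compounds carry 2-chlorophenyl there, so no measured step speaks directly to this change. The step at the ring nitrogen (a 2.3-fold lower number from compound 1 to compound 2 (0.37 log units; beyond the scatter)) bears on it only loosely, as a sign of how modest a single change has been so far in this series. With no direction available from the data, no step beyond the scatter is expected in this assay, and the estimate stays anchored on compound 2 (8010 nM), with a wide range.

The expected step is small (a 1.1-fold lower number from compound 2 to compound 3 (0.06 log units; within the scatter)). For compound 3 the estimated value is 7000 nM, with an expected range of 2500 nM to 20000 nM.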

Compound 3, half-maximal inhibitory concentration: 14900 nM
The estimate for compound 3 lay 2.1-fold (0.33 log units) below the measured number; low and high end bracket the measured number.
By their numbers in this assay, from the lowest: compounds 2, 3 and 1 (each within the scatter of the next, the first and the last beyond it).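

In this assay the first change seen on the carbonyl carbon gives a 1.9-fold higher number from compound 2 to compound 3 (0.27 log units; within the scatter) and so stays within the usual scatter. With the 2,4-dichlorobenzyl group held on the ring nitrogen, 4-(trifluoromethyl)phenyl and 2-chlorophenyl cannot be told apart on this read-out, so this position tolerates the exchange of one for the other without a step beyond the scatter. No supporting measurement bears on why the two groups read alike, and the result is recorded here only as an observation.

On these data alone, it remains open whether the step at the ring nitrogen, a 2.3-fold lower number from compound 1 to compound 2 (0.37 log units; beyond the scatter) in the series carrying 2-chlorophenyl, would carry over when 4-(trifluoromethyl)phenyl sits on the carbonyl carbon. Two aryl groups also say little about the wider range of this position, where an amine, a carboxylic acid or a longer alkyl chain on the carbonyl carbon could still produce a step beyond the scatter in either direction.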